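Cyano in Place of Methyl on the Benzyl Group

This account rests on a few compounds, and the source may have more. Where it says the series, first, only, none or still open, it means among the compounds named here.

Compound 1 `Cc1cccc(Cc2nc3cc(O[C@H]4CC[C@@H](C(=O)O)CC4)ccc3o2)c1`: 39 nM
Compound 2 `Cc1cccc(Cc2nc3cc(O[C@H]4CC[C@@H](C(=O)O)CC4)ccc3n2C)c1`: 42 nM

In an assay on isolated protein for inhibition of Long-chain-fatty-acid--CoA ligase 1 (Homo sapiens), read by mass spectrometry, with a stated time of 90 min, in the presence of a further agent that is not named here (a higher number here means a weaker inhibitor, a lower number a stronger inhibitor), compound 1 gives 39 nM and compound 2 gives 42 nM. Compound 2 holds the higher of the two numbers, yet its nearest neighbour, compound 1, lies within the usual scatter, so the two cannot be told apart. Compound 3 `Cn1c(Cc2cccc(C#N)c2)nc2cc(O[C@H]3CC[C@@H](C(=O)O)CC3)ccc21` differs from compound 2 by cyano in place of methyl on an aromatic carbon. For the measured compounds named here, no step between measured compounds of this kind exists, so the expectation rests on the change alone. A modest weakening is expected, a 1.7-fold higher number from compound 2 to compound 3 (0.22 log units; within the scatter). Compound 3 is estimated at 70 nM, with a range from 20 nM to 250 nM.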

Compound 3, half-maximal inhibitory concentration: 51000 nM
Beside the measured number, compound 3's estimate is 730-fold (2.86 log units) below it; the measured number lies above the stated range.
By their numbers in this assay, from the lowest: compounds 1 and 2 (each within the scatter of the next); then compound 3.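

The 3-methylbenzyl group proved far less tolerant than the near-equal values of compounds 1 and 2 could show: in this assay, cyano in place of methyl on this aromatic carbon gives a 1200-fold higher number from compound 2 to compound 3 (3.08 log units; beyond the scatter). A single change on the benzyl ring, away from the carboxylic acid, is thus enough to lose nearly all of the inhibition. No measurement shown here accounts for this loss. Going by these compounds, whether a chloro, methoxy or ethyl group at this place would keep the value of compound 2 remains open, as does the effect of cyano on the core of compound 1.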